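A few compounds are considered here, and "the series" means these few. Any claim that something is new, unique, unknown or untested is made for them only; others in the source may bear on it.

Compound 1 `CCCCCCCCc1ccc(OCC(=O)Cn2nnc(C)n2)cc1` gives 27 nM in an assay on microsomes from brain for inhibition of Fatty-acid amide hydrolase 1 (Rattus norvegicus), read by fluorescence and HPLC, with a stated time of 60 min (a higher number here means a weaker inhibitor, a lower number a stronger inhibitor), the lowest of the two numbers available. Its nearest neighbour is compound 2 `CCCCCCCCc1ccc(OCC(=O)Cn2nnc(CCC(=O)O)n2)cc1`, which gives 30 nM in this assay; the step of a 1.1-fold higher number from compound 1 to compound 2 (0.05 log units; within the scatter) shows that carboxymethyl in place of hydrogen on the tetrazole of compound 1 leaves the number essentially where it was. Compound 3 `CCCCCCCCc1ccc(OCC(=O)Cn2nnnc2SC)cc1` has not been measured. It differs from compound 1 as follows: 5-(methylsulfanyl)-1H-tetrazol-1-yl in place of 5-methyl-2H-tetrazol-2-yl on a saturated chain carbon bound to a carbonyl carbon. Among the measured compounds shown here, the only measured step, from compound 1 to compound 2, also alters the tetrazole and is within the scatter, so it bears on this change only loosely and gives no reason to expect a large step in either direction; the move from 5-methyl-2H-tetrazol-2-yl to 5-(methylsulfanyl)-1H-tetrazol-1-yl itself is covered by no measured pair. Compound 3 is therefore expected to give about 35 nM in this assay, between 12 nM and 100 nM, a step of a 1.3-fold higher number from compound 1 to compound 3 (0.11 log units; within the scatter) expected to stay within the scatter.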

Compound 3, half-maximal inhibitory concentration: 22 nM
Compound 3: middle estimate off by 1.6-fold (0.20 log units), on the high side; the range from low to high includes it.
By their numbers in this assay, from the lowest: compounds 3, 1 and 2 (each within the scatter of the next).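

In this assay, putting 5-(methylsulfanyl)-1H-tetrazol-1-yl in place of 5-methyl-2H-tetrazol-2-yl on a saturated chain carbon bound to a carbonyl carbon gives a 1.2-fold lower number from compound 1 to compound 3 (0.09 log units; within the scatter) and so leaves the number within the scatter. The earlier step altered only a substituent on the tetrazole, whereas this change replaces the entire group, and even so the number does not move beyond the scatter. No measurement in hand explains why the number holds.

The compounds shown leave open how much each part of the change contributes, since neither 5-methyl-1H-tetrazol-1-yl nor 5-(methylsulfanyl)-2H-tetrazol-2-yl is among them. They also leave open whether the number would hold with an amine on the tetrazole, or with a longer chain such as octylsulfanyl in place of methylsulfanyl.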